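Five-Membered Oxazole in Place of Pyridine on a Silent Core

A few compounds are considered here, and "the series" means these few. Any claim that something is new, unique, unknown or untested is made for them only; others in the source may bear on it.

Of the compounds shown here, three sharing one core have been tested in a functional assay on CHO cells for agonist activity at Alpha-1D adrenergic receptor (Homo sapiens), read by FLIPR and calcium flux; on this read-out higher numbers stand for an effect only at larger amounts of compound and lower numbers for an effect already at smaller amounts. Compound 1 `c1ccc(-c2cccc3c2CCC3c2ncc[nH]2)nc1` gives only a limit of the assay, > 10000 nM. Compound 2 `Cn1ccc(-c2cccc3c2CCC3c2ncc[nH]2)n1` likewise gives only a limit, > 10000 nM. Compound 3 `c1cncc(-c2cccc3c2CCC3c2ncc[nH]2)c1` also sits at a limit, > 10000 nM. The steps a step that the two limits leave unreadable from compound 1 to compound 2, a step that the two limits leave unreadable from compound 1 to compound 3 and a step that the two limits leave unreadable from compound 2 to compound 3 therefore cannot be sized; all the evidence available is the limit of > 10000 nM in this assay, at which 3 of the 3 values shown sit. Compound 3 thus stands at a limit, with no number of its own, as do the other two.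

Compound 4 `c1cc(-c2ncco2)c2c(c1)C(c1ncc[nH]1)CC2` differs from compound 3 in one place: 1,3-oxazol-2-yl in place of pyridin-3-yl on an aromatic carbon. Going by the values given here, no measured step bears on this change in a readable way; each step among the measured compounds is hidden by the limit of > 10000 nM in this assay, at which 3 of the 3 values shown sit. With nothing pointing to a gain, compound 4 is expected to remain at or near the limit, a step that the limit leaves unreadable from compound 3 to compound 4. The estimate for compound 4 in this assay is 20000 nM, with a range from 4000 nM to 100000 nM.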

Compound 4, half-maximal effective concentration: 1390 nM
Estimate against measurement, compound 4: 14-fold (1.16 log units) above; measured number outside the range, below it.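

In this assay, 1,3-oxazol-2-yl is the only group shown on this aromatic carbon of the shared core that gives a measured number rather than a limit, so the position can respond to a change of group. The change to 1,3-oxazol-2-yl gives an at least 7.1-fold lower number from compound 3 to compound 4 (0.85 log units; beyond the scatter), an at least 7.1-fold lower number from compound 2 to compound 4 (0.85 log units; beyond the scatter) and an at least 7.1-fold lower number from compound 1 to compound 4 (0.85 log units; beyond the scatter), and each of these sets only a minimum for the size of the step. Compound 2, with 1-methyl-1H-pyrazol-3-yl, also carries a five-membered aromatic ring and still sits at a limit, so ring size alone does not set the outcome here: the limit of > 10000 nM in this assay, at which 3 of the 4 values shown sit.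

The compounds shown leave open which feature of 1,3-oxazol-2-yl goes with the lower number. Also open, going by these compounds, is whether a 1,3-thiazol-2-yl, an amine or a carboxylic acid on this carbon would give a measured number.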